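Working notes: aryl swap on the carbonyl carbon

The source may report more compounds than this note shows. Statements on the series, on what has been measured and on what is new or still open speak of the compounds shown alone.

Measured so far:
compound 1 `COc1ccc(-c2cc(/C=C/C(=O)c3ccc(OC)c(OC)c3)[nH]n2)cc1`: 98%
compound 2 `COc1cc(-c2cc(/C=C/C(=O)c3ccc(Cl)c(Cl)c3)[nH]n2)cc(OC)c1OC`: 91%

In a functional assay on CAKI-1 cells (Homo sapiens) for cytotoxicity, read by sulforhodamine B assay, with a stated time of 48 h, tested at 0.01 uM (a lower number here means a stronger effect, a higher number a weaker effect of the compound at the concentration tested), compound 2 gives 91% and compound 1 gives 98%; the two numbers lie within the scatter of each other, so compound 2 stands level with compound 1. Compound 3 `COc1ccc(C(=O)/C=C/c2cc(-c3cc(OC)c(OC)c(OC)c3)n[nH]2)cc1OC` is not yet measured. It differs from compound 2 by 3,4-dimethoxyphenyl in place of 3,4-dichlorophenyl on a carbonyl carbon. Within the data shown here, no measured pair shows this change, but compound 1 already carries the 3,4-dimethoxyphenyl on the carbonyl carbon with 98%, so no step beyond the scatter is expected. The expected step is a number 4 percentage points higher from compound 2 to compound 3 (within the scatter). For compound 3 the estimate is 95%, range 84% to 102%.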

Compound 3, a percentage reported as activity, at one concentration (the size of the read-out at that concentration, not a potency): 97%
Beside the measured number, compound 3's estimate is 2 percentage points below it, within the range that was stated.
By their numbers in this assay, from the lowest: compounds 2, 3 and 1 (each within the scatter of the next).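

In this assay, among these compounds, 3,4-dimethoxyphenyl in place of 3,4-dichlorophenyl on a carbonyl carbon gives a number 6 percentage points higher from compound 2 to compound 3 (within the scatter), the first direct reading of this change with the rest of the molecule held constant. At this one concentration, the two groups are therefore not told apart at this position. No measured evidence bears on the reason for this result. Open, from the compounds shown here alone, is whether a phenyl carrying an amine or a carboxylic acid at this place would give a step beyond the scatter from compound 2. Also open, going by these compounds, is whether compound 2 and compound 3 would separate at a higher concentration.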